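The source may report more compounds than this note shows. Statements on the series, on what has been measured and on what is new or still open speak of the compounds shown alone.

Compound 1 `Cc1cc(C(=O)/C=C/c2cc3cccc(C)c3nc2Cl)c(C)s1`: "not determined" (no result reported)
Compound 2 `Cc1cccc2cc(/C=C/C(=O)c3ccc(Br)s3)c(Cl)nc12`: 243 nM

Going by the values given here, in a functional assay on HUVEC cells (Homo sapiens), read by BrdU incorporation, with a stated time of 72 h (a lower number here means a stronger inhibitor, a higher number a weaker inhibitor), compound 2 gives 243 nM and this is the only number so far. Compound 1 has no reported result, so compound 2 cannot yet be ranked against anything.

The change from compound 2 to compound 3 `Cc1ccc(C(=O)/C=C/c2cc3cccc(C)c3nc2Cl)s1` is methyl in place of bromo on an aromatic carbon and in words it is methyl in place of bromo on an aromatic carbon, next to the ring sulfur. Among the compounds with values here, no measured pair shows what this swap does, so the data give no guide to its size or direction. The expectation in this assay is therefore no step beyond the usual scatter, in neither direction. The estimated change is a 1.1-fold higher number from compound 2 to compound 3 (0.03 log units; within the scatter) and the wide range reflects how little is known. For compound 3 the estimate is 260 nM with an expected range from 90 nM to 750 nM.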

Compound 3, half-maximal inhibitory concentration: 145 nM
Compound 3: middle estimate off by 1.8-fold (0.25 log units), on the high side; the measured number falls inside the stated range.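

Going by these compounds alone, replacing 5-bromothiophen-2-yl with 5-methylthiophen-2-yl gives a 1.7-fold lower number from compound 2 to compound 3 (0.22 log units; within the scatter) in this assay, the first measured step at this position. Within this single pair, bromo and methyl cannot be told apart, so exchanging one for the other on this aromatic carbon, next to the ring sulfur, does not move the result beyond the usual spread of repeated measurements. Nothing available here explains why the two groups give such similar results.

From the compounds shown here alone, whether this holds beyond bromo and methyl stays open, since a single pair cannot show what a bare hydrogen, an amine, a carboxylic acid or a longer chain such as propyl would do in this place. The effect of the additional ring methyl in compound 1 also cannot be read, as compound 1 has the entry "not determined" (no result reported) in this assay.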